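The source may hold more compounds than are shown below. What is called first, only, known or untested is meant among the compounds shown, and "the series" means these compounds.

Compound 1, `CN(C)c1ncnc2c1c(-c1ccsc1)cn2[C@@H]1O[C@H](CO)[C@@H](O)[C@H]1O`, in a functional assay on A549 cells (Homo sapiens), read by MTT assay, with a stated time of 72 h (on this read-out higher numbers stand for weaker inhibition and lower numbers for stronger inhibition), gives > 20000 nM, which is a limit of the assay rather than a number.
Compound 2, `Cc1nc(N)c2c(-c3cccs3)cn([C@@H]3O[C@H](CO)[C@@H](O)[C@H]3O)c2n1`, in this assay gives > 20000 nM, again a limit.
Compound 3, `Cc1ncnc2c1c(-c1cccs1)cn2[C@@H]1O[C@H](CO)[C@@H](O)[C@H]1O`, in this assay gives > 20000 nM, also a limit.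

On the numbers shown compound 2 stands at no particular place: each of the three values is a limit, and (the limit of > 20000 nM in this assay, at which 3 of the 3 values shown sit). Among the compounds with values here, none of the three compounds can be called stronger or weaker than another, and no pair among them differs in only one place, so no measured step is available to lean on.

Compound 4, `Cc1nc(N)c2c(-c3ccsc3)cn([C@@H]3O[C@H](CO)[C@@H](O)[C@H]3O)c2n1`, has not yet been measured. It differs from compound 2 in a single way: thiophen-3-yl in place of thiophen-2-yl on an aromatic carbon. The thiophen-3-yl group already appears in compound 1 and the thiophen-2-yl group in compounds 2 and 3, and all three of those compounds sit at the limit. The step in this assay is expected to be none beyond the scatter, with the outcome most likely a limit once more. Compound 4 is expected to give about 30000 nM, within a range from 10000 nM to 100000 nM. The step that the limit leaves unreadable from compound 2 to compound 4 is expected to stay within the scatter.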

Compound 4, half-maximal inhibitory concentration: > 20000 nM
Compound 4: no number, only a limit (the forecaster's own chance of this, stated with the estimate: 85%); the middle value lies beyond the limit too.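

Compound 2 and compound 4 both end at a limit of the assay rather than a number, so the swap of thiophen-2-yl for thiophen-3-yl gives no step that can be read in this assay: the limit of > 20000 nM in this assay, at which 4 of the 4 values shown sit.

The compounds shown leave open whether this swap changes inhibition at all, and whether any compound with this shared core gives a readable number.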